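The compounds below may be only part of what the source reports. "The series", "measured", "known", "first", "only" and "open" are said of these compounds alone.

Measured so far in a functional assay on MOLT-4 cells (Homo sapiens) for antiproliferative activity, read by CCK-8 assay, with a stated time of 72 h; a higher number here means a weaker inhibitor, a lower number a stronger inhibitor:
Compound 1 `COc1cccc(Nc2nc(Nc3cc(C)[nH]n3)cc(N3CCN(C)CC3)n2)c1`: 192 nM
Compound 2 `Cc1cc(Nc2cc(N3CCN(C)CC3)nc(Nc3cccc([N+](=O)[O-])c3)n2)n[nH]1`: 26 nM

Compound 2 has the lower of the two numbers, which makes it the stronger inhibitor. Compound 3 `Cc1cc(Nc2cc(N3CCN(C)CC3)nc(Nc3cccc(Cl)c3)n2)n[nH]1` keeps everything in compound 2 except one group, with chloro in place of nitro on an aromatic carbon. Going by the values given here, only one measured step bears on this: a 7.4-fold lower number from compound 1 to compound 2 (0.87 log units; beyond the scatter), a modest change at that same place when nitro replaced methoxy. Among the compounds with values here, it shows that the group there matters, but no chloro compound has been measured. A small shift towards a higher number in this assay is therefore expected. The estimated step is a 1.7-fold higher number from compound 2 to compound 3 (0.24 log units; within the scatter). For compound 3 the expected value is 45 nM, with an estimated range of 15 nM to 140 nM.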

Compound 3, half-maximal inhibitory concentration: 20.1 nM
Compound 3: middle estimate off by 2.2-fold (0.35 log units), on the high side, within the range that was stated.
By their numbers in this assay, from the lowest: compounds 3 and 2 (each within the scatter of the next); then compound 1.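

In this assay chloro in place of nitro gives a 1.3-fold lower number from compound 2 to compound 3 (0.11 log units; within the scatter) and so cannot be told apart from nitro, even though one heavy atom stands where there were three. Chloro in place of methoxy gives a 9.6-fold lower number from compound 1 to compound 3 (0.98 log units; beyond the scatter) and matches what nitro did, leaving compound 1 as the weakest of the three. Nothing measured here explains this result. The compounds shown leave open how an amine, a carboxylic acid or a longer chain would fare at this place on the ring.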